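Methoxy for methyl at a stability limit

A few compounds are considered here, and "the series" means these few. Any claim that something is new, unique, unknown or untested is made for them only; others in the source may bear on it.

In an ADME assay on microsomes from liver (Canis lupus familiaris) for metabolic stability (a higher number here means that the compound lasts longer, a lower number that the compound disappears faster), compound 1 (`Nc1nc(NCCNc2ncc(-c3ncc[nH]3)c(-c3ccc(Br)cc3F)n2)ccc1[N+](=O)[O-]`) gives > 0.5 h, which is a limit of the assay and not a number. Compound 2 (`Cc1cc(Cl)ccc1-c1nc(NCCNc2ccc([N+](=O)[O-])c(N)n2)ncc1-c1ncc[nH]1`) gives > 0.5 h, which is likewise a limit and not a number. The record therefore holds only (the limit of > 0.5 h in this assay, at which 2 of the 2 values shown sit). For the measured compounds named here, its single measured step is a step that the two limits leave unreadable from compound 1 to compound 2, and that offers no size to carry forward.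

Compound 3 (`COc1cc(Cl)ccc1-c1nc(NCCNc2ccc([N+](=O)[O-])c(N)n2)ncc1-c1ncc[nH]1`) differs from compound 2 by methoxy in place of methyl on an aromatic carbon, ortho to a large group. With no readable step to draw on, no step beyond the scatter is expected in this assay, and another limit is a likely report. The expected step is a step that the limit leaves unreadable from compound 2 to compound 3. Compound 3 is estimated at 0.6 h, with an expected range from 0.3 h to 1.2 h.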

Compound 3, half-life: > 0.5 h
Compound 3 was reported as a limit; the forecaster's own chance of this, stated with the estimate: 75%; the middle value does not contradict the limit.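

In this assay compound 3 gives > 0.5 h as a limit and not a number. For the compounds shown here, no step among compound 1, compound 2 and compound 3 can be read, because all three stand at the same limit: the limit of > 0.5 h in this assay, at which 3 of the 3 values shown sit. The compounds shown leave open how long each of the three actually lasts, and so whether methoxy and methyl differ here at all.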